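Fluoro on the methoxyphenyl ring in two ring-fused cores

This account rests on a few compounds, and the source may have more. Where it says the series, first, only, none or still open, it means among the compounds named here.

Measured compounds:
compound 1 `COc1ccc(/C=C2\Cc3c(cc(OC)c(OC)c3OC)C2=O)cc1`: 750 nM
compound 2 `COc1ccc(/C=C2\Cc3c(cc(OC)c(OC)c3OC)C2=O)cc1F`: 277 nM
compound 3 `COc1ccc(/C=C2\CCc3c(cc(OC)c(OC)c3OC)C2=O)cc1`: 19600 nM

All three were run in a functional assay on PC-3 cells (Homo sapiens) for antiproliferative activity, read by MTT assay, with a stated time of 48 h; a higher number here means a weaker inhibitor of growth, a lower number a stronger inhibitor of growth. Compound 1 and compound 2 share one core and differ by fluoro in place of hydrogen on an aromatic carbon; this gave a 2.7-fold lower number from compound 1 to compound 2 (0.43 log units; beyond the scatter). Compound 3 has a different core, and in this assay compound 3 gives 19600 nM; the difference between the two cores is not broken down here. Among the measured compounds shown here, compound 4 `COc1ccc(/C=C2\CCc3c(cc(OC)c(OC)c3OC)C2=O)cc1F` is the unmeasured partner of compound 3 and differs from it by fluoro in place of hydrogen on an aromatic carbon, the same change as the one from compound 1 to compound 2. For the measured compounds named here, the step from compound 3 to compound 4 in this assay is expected to be about a 2.7-fold lower number from compound 3 to compound 4 (0.43 log units; beyond the scatter), resting on the single precedent of compound 1 to compound 2 with a 2.7-fold lower number from compound 1 to compound 2 (0.43 log units; beyond the scatter). Compound 4 is therefore estimated at 7200 nM, with a range from 3200 nM to 16000 nM.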

Compound 4, concentration for 50% growth inhibition: 27600 nM
Beside the measured number, compound 4's estimate is 3.8-fold (0.58 log units) below it; measured number above the stated range.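

In this assay, fluoro in place of hydrogen on the core of compound 3 gives a 1.4-fold higher number from compound 3 to compound 4 (0.15 log units; within the scatter) and so does not repeat the earlier gain. In this series, the effect of the change does not carry over from one core to the other: the same change on two cores in this assay, a 2.7-fold lower number (0.43 log units; beyond the scatter) from compound 1 to compound 2 and a 1.4-fold higher number (0.15 log units; within the scatter) from compound 3 to compound 4, 3.8-fold (0.58 log units) apart, beyond the scatter of two such steps. With one pair on each core, this shows a dependence on the core for these compounds only, and it does not show which feature of the cores is responsible or how the change would behave on a further core.

Going by these compounds, it remains open whether chloro or an amine, ortho to a methoxy group, would depend on the core in the same way. Also open, on these data alone, is whether a hydroxy group in place of that methoxy group would alter the result on either core.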